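Compound 1 to compound 4: a larger aromatic group

The source may report more compounds than this note shows. Statements on the series, on what has been measured and on what is new or still open speak of the compounds shown alone.

Among the compounds with values here, in a functional assay on NCI-H1993 cells (Homo sapiens) for inhibition, read by CCK-8 assay, with a stated time of 72 h (on this read-out higher numbers stand for weaker inhibition and lower numbers for stronger inhibition), compound 1 (`CC(c1cc2cccnc2cc1F)n1cnc2ncc(-c3cn[nH]c3)nc21`) gives 187 nM as the only number so far. In this assay, within the data shown here, compound 2 (`CCC(c1cc2cccnc2cc1F)n1cnc2ncc(-c3cn[nH]c3)nc21`) stands at "not determined" (no result reported) and compound 3 (`CCC(c1cc2cccnc2cc1F)n1cnc2ncc(-c3ccccc3)nc21`) stands at "not determined" (no result reported), so compound 1 cannot yet be ranked against any neighbour and no measured step is available as a guide.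

Compound 4 (`COC(=O)c1ccc(-c2cnc3ncn(C(C)c4cc5cccnc5cc4F)c3n2)cc1F`) keeps the core of compound 1 and differs in one place (3-fluoro-4-(methoxycarbonyl)phenyl in place of 1H-pyrazol-4-yl on an aromatic carbon), on an aromatic carbon of the six-membered aromatic ring with 2 nitrogen. The hydrogen-bond donor of the 1H-pyrazol-4-yl group does not return in the 3-fluoro-4-(methoxycarbonyl)phenyl group.

With nothing measured to size this change, the expectation in this assay is tentative and leans towards weaker inhibition, although a result within the scatter would not be surprising. The expected step of a 1.6-fold higher number from compound 1 to compound 4 (0.21 log units; within the scatter) is a modest weakening. For compound 4 the estimated value is 300 nM (expected range 60 nM to 1500 nM).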

Compound 4, half-maximal inhibitory concentration: 60.2 nM
Estimate against measurement, compound 4: 5.0-fold (0.70 log units) above; the range from low to high includes it.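

In this assay, within the data shown here, 3-fluoro-4-(methoxycarbonyl)phenyl in place of 1H-pyrazol-4-yl on this aromatic carbon gives a 3.1-fold lower number from compound 1 to compound 4 (0.49 log units; beyond the scatter) as the first measured step. This one pair shows that the position accepts a larger group, a six-membered aromatic ring of carbon only with two substituents, and that inhibition in these cells does not fall when the hydrogen-bond donor of 1H-pyrazol-4-yl is gone.

As far as these compounds go, with a single pair, the parts played by the fluorine, the methoxycarbonyl group and the carbon-only ring cannot be told apart, and it remains open how a carboxylic acid or a primary amide in place of the methoxycarbonyl group would read. No measurement at hand accounts for the size of this step.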